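A piperidine amide in place of a chloromethyl group

This account rests on a few compounds, and the source may have more. Where it says the series, first, only, none or still open, it means among the compounds named here.

Compound 1, `CO[C@H]1C[C@H](O[Si](C)(C)C(C)(C)C)O[C@@H](C)/C1=C\C(=O)O`: 0.002 ug/mL
Compound 2, `CO[C@H]1C[C@H](O[Si](C)(C)C(C)(C)C)O[C@@H](C)/C1=C\COC(=O)c1ccncc1`: 0.01 ug/mL
Compound 3, `CO[C@H]1C[C@H](O[Si](C)(C)C(C)(C)C)O[C@@H](C)/C1=C/CCl`: 0.01 ug/mL

These three compounds share one core and were tested in a functional assay on the whole organism for inhibition, with Artemia salina as the target; a lower number here means a stronger inhibitor of growth, a higher number a weaker inhibitor of growth. Compound 3 gives 0.01 ug/mL, level with compound 2 at the digits shown, and the two together hold the highest of the three numbers; compound 2 is its nearest neighbour, with no change beyond the scatter. Furthest from it lies compound 1, whose number is clearly lower, a gap beyond the scatter.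

Compound 4, `CO[C@H]1C[C@H](O[Si](C)(C)C(C)(C)C)O[C@@H](C)/C1=C/C(=O)N1CCCCC1`, has not yet been measured. It differs from compound 3 by (piperidin-1-yl)carbonyl in place of chloromethyl on a double-bonded chain carbon bound to a double-bonded ring carbon. Within the data shown here, no step between measured compounds matches this change, so nothing in the data fixes its size. Compound 2 and compound 3 give the same number at the digits shown although their chains differ, while compound 1 stands apart. On that basis the step is expected to stay within the scatter: no change at the digits printed from compound 3 to compound 4 (within the scatter). Compound 4 is therefore estimated at 0.01 ug/mL, within a range from 0.002 ug/mL to 0.05 ug/mL.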

Compound 4, minimum inhibitory concentration: 0.002 ug/mL
The estimate for compound 4 lay 2.3 two-fold dilutions above the measured number, and the stated range covers the measured number.
By their numbers in this assay, from the lowest: compounds 1 and 4 (each within the scatter of the next); then compounds 2 and 3 (each within the scatter of the next).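

In this assay, among these compounds, (piperidin-1-yl)carbonyl in place of chloromethyl on a double-bonded chain carbon bound to a double-bonded ring carbon gives a number 2.3 two-fold dilutions lower from compound 3 to compound 4 (beyond the scatter), the first step that can be read between measured compounds differing in one place. It shows that the number in this assay responds to what this position carries, something the matching values of compound 2 and compound 3 gave no sign of. Nothing measured on these compounds accounts for the step, so its cause remains unknown.

The compounds shown leave open whether the step belongs to the carbonyl or to the piperidine ring. A morpholine amide, a dimethylamide or a methyl ester at the same place would separate the two.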